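Swapping Bromo for Chloro on an Aromatic Carbon

The source may hold more compounds than are shown below. What is called first, only, known or untested is meant among the compounds shown, and "the series" means these compounds.

Measured in a functional assay on cells (T-cell, Mus musculus) for inhibition; on this read-out lower numbers stand for stronger inhibition and higher numbers for weaker inhibition:
- compound 1 `Nc1nc(N)c2nc(CNc3ccc(C(=O)N[C@@H](CC(F)C(=O)O)C(=O)O)cc3C(F)(F)F)cnc2n1`: 0.0168 ug/mL; 0.008 ug/mL (2 entries)
- compound 2 `Cc1cc(C(=O)N[C@@H](CC(F)C(=O)O)C(=O)O)ccc1NCc1cnc2nc(N)nc(N)c2n1`: 0.0078 ug/mL; 0.0107 ug/mL (2 entries)
- compound 3 `Nc1nc(N)c2nc(CNc3ccc(C(=O)N[C@@H](CC(F)C(=O)O)C(=O)O)cc3Br)cnc2n1`: 0.0021 ug/mL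

Compound 3 has just one number, 0.0021 ug/mL, and two further entries for it give no single number. That number lies lower, meaning stronger inhibition, than the repeated entries of the other two compounds: the several entries of compound 1 in this assay, 0.0168 ug/mL; 0.008 ug/mL (2 entries) and (the several entries of compound 2 in this assay, 0.0078 ug/mL; 0.0107 ug/mL (2 entries)).

Compound 4 `Nc1nc(N)c2nc(CNc3ccc(C(=O)N[C@@H](CC(F)C(=O)O)C(=O)O)cc3Cl)cnc2n1` has not yet been measured. It differs from compound 3 by one small exchange, (chloro in place of bromo on an aromatic carbon), with chloro in place of bromo on an aromatic carbon. For the measured compounds named here, no measured pair shows what this exchange does, so any forecast is tentative. A small move toward a higher number in this assay is expected, and it may not clear the usual scatter. This lean rests on compound 3 having a single number, 0.0021 ug/mL, while compound 2 sits higher at 0.0078 ug/mL; 0.0107 ug/mL (2 entries). The expected step is a 1.9-fold higher number from compound 3 to compound 4 (0.28 log units; within the scatter). For compound 4 the estimated value is 0.004 ug/mL, with an expected range from 0.0015 ug/mL to 0.012 ug/mL.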

Compound 4, half-maximal inhibitory concentration: 0.0043 ug/mL
The estimate for compound 4 lay 1.1-fold (0.03 log units) below the measured number; measured number inside the range.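

For the compounds shown here, the exchange of bromo for chloro gives the first measured step at this position in this assay, a 2.0-fold higher number from compound 3 to compound 4 (0.31 log units; beyond the scatter), so a change of halogen alone on this aromatic carbon is enough to shift the number modestly. The two groups match in everything counted for them except the element, and the shared core stays the same. Still, the step is small: repeated entries for a single compound at this position can spread by a similar amount, as the trifluoromethyl analogue shows: the several entries of compound 1 in this assay, 0.0168 ug/mL; 0.008 ug/mL (2 entries)

From the compounds shown here alone, compound 3 and compound 4 each rest on one number here, so whether the step holds on repetition stays open. Going by these compounds, what fluoro, a methoxy group or an amine on this same carbon would do also remains open.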